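This account rests on a few compounds, and the source may have more. Where it says the series, first, only, none or still open, it means among the compounds named here.

Working notes on the series. For the measured compounds named here, in an ADME assay on MT4 cells (Homo sapiens) for cytotoxicity, read by MTT assay, with a stated time of 5 days (on this read-out higher numbers stand for lower toxicity in this test and lower numbers for higher toxicity in this test), compound 1 (`Cc1cc(C)cc(S(=O)(=O)c2c(C(=O)N[C@@H]3CCN(CC(N)=O)C3)[nH]c3ccc(Cl)cc23)c1`) gives 31000 nM and compound 2 (`CCCS(=O)(=O)NC(=O)c1[nH]c2ccc(Cl)cc2c1S(=O)(=O)c1cc(C)cc(C)c1`) gives 146000 nM, the higher of the two numbers so far. Next is compound 3 (`Cc1cc(C)cc(S(=O)(=O)c2c(C(=O)NS(=O)(=O)c3ccccc3)[nH]c3ccc(Cl)cc23)c1`), which carries phenyl in place of propyl on a sulfonyl sulfur. Going by the values given here, the only measured step is a 4.7-fold higher number from compound 1 to compound 2 (0.67 log units; beyond the scatter), a modest one, where propylsulfonyl took the place of 1-(carbamoylmethyl)pyrrolidin-3-yl on an amide-type nitrogen. Among the compounds with values here, compound 3 keeps the sulfonyl on that nitrogen, and no measured step changes the group on the sulfur, so this evidence bears only loosely. A modest step to a lower number is expected, no larger than the measured one, and it may stay within the scatter. The expected change is a 1.8-fold lower number from compound 2 to compound 3 (0.26 log units; within the scatter). For compound 3 the estimated value is 80000 nM, with an expected range of 28000 nM to 200000 nM.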

Compound 3, half-maximal cytotoxic concentration: 167000 nM
Compound 3: the middle estimate sits 2.1-fold (0.32 log units) below what was measured, and the stated range covers the measured number.
By their numbers in this assay, from the lowest: compound 1; then compounds 2 and 3 (each within the scatter of the next).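

In this assay, phenyl in place of propyl on a sulfonyl sulfur gives a 1.1-fold higher number from compound 2 to compound 3 (0.06 log units; within the scatter), so this change at the sulfonyl sulfur, which brings in a six-membered aromatic ring, shows no effect beyond the scatter. The step away from 1-(carbamoylmethyl)pyrrolidin-3-yl on the amide-type nitrogen now reads with a second sulfonyl group, as a 5.4-fold higher number from compound 1 to compound 3 (0.73 log units; beyond the scatter), and it is again beyond the scatter, as it was with propylsulfonyl. No supporting data on the compounds accompany this result.

Open, as far as these compounds go, is whether a longer chain on the sulfonyl sulfur, or an amine or a carboxylic acid carried on the phenyl, would keep the number at this level. Also open, from the compounds shown here alone, is whether a sulfonyl group on the amide-type nitrogen gives the same result with other groups on the shared core.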